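Chalcone-type pyrazoles: cytotoxicity on lung cancer cells

The source may report more compounds than this note shows. Statements on the series, on what has been measured and on what is new or still open speak of the compounds shown alone.

Measured so far:
compound 1 `COc1ccc(-c2cc(/C=C/C(=O)c3ccc(OC)c(OC)c3)[nH]n2)cc1` gives 111%
compound 2 `COc1cc(-c2cc(/C=C/C(=O)c3ccc(Cl)c(Cl)c3)[nH]n2)cc(OC)c1OC` gives 89%

Both readings come from a functional assay on NCI-H522 cells (Homo sapiens) for cytotoxicity, read by sulforhodamine B assay, with a stated time of 48 h, tested at 0.1 uM; a higher number here means a weaker effect of the compound at the concentration tested, a lower number a stronger effect. Of the two, compound 2 stands lowest, and the gap to compound 1 is beyond the usual scatter of the assay, so compound 2 is the stronger of the pair at this concentration. Within the data shown here, no pair of measured compounds differs in only one place, so no step from the numbers themselves is available.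

Compound 3 `COc1ccc(C(=O)/C=C/c2cc(-c3cc(OC)c(OC)c(OC)c3)n[nH]2)cc1OC` is not yet measured. It differs from compound 2 in a single place: 3,4-dimethoxyphenyl in place of 3,4-dichlorophenyl on a carbonyl carbon. The remainder of compound 2 is kept. Compound 1 also carries the 3,4-dimethoxyphenyl on the carbonyl carbon, though with a different group on the core, so it cannot be read as a matched pair with compound 3.

Given that compound 1 sits higher than compound 2, the step from compound 2 to compound 3 is expected to be upward, toward a weaker effect, by about a number 11 percentage points higher from compound 2 to compound 3 (beyond the scatter), but a step within the scatter cannot be excluded. Compound 3 is estimated at 100%, within a range from 85% to 115% in this assay.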

Compound 3, a percentage reported as activity, at one concentration (the size of the read-out at that concentration, not a potency): 91%
Estimate against measurement, compound 3: 9 percentage points above; low and high end bracket the measured number.
By their numbers in this assay, from the lowest: compounds 2 and 3 (each within the scatter of the next); then compound 1.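

With 3,4-dimethoxyphenyl in place of 3,4-dichlorophenyl on a carbonyl carbon, this assay shows a number 2 percentage points higher from compound 2 to compound 3 (within the scatter), so at this single concentration the two groups cannot be told apart. Among these compounds, this is the first pair that differs in one place only, and it gives this position a reading that compound 1 and compound 2 could not give, since those two differ in more than one place. The exchange adds two oxygen atoms and removes both chlorine atoms, yet it leaves the read-out within the scatter. The data on hand offer no measurement that would account for this outcome.

Still open, going by these compounds, is whether a clearly different group on the carbonyl carbon, such as a phenyl ring carrying an amine or a carboxylic acid, would separate from these two in this assay. Also open, on these data alone, is what the group on the core contributes on its own, and whether the two groups at this position would still read alike at a concentration where the compounds have a larger effect.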